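Aryl in place of alkyl on the acylguanidine core

This account rests on a few compounds, and the source may have more. Where it says the series, first, only, none or still open, it means among the compounds named here.

Measured compounds and their values in a functional assay for inhibition of sodium/hydrogen exchanger (Oryctolagus cuniculus); on this read-out higher numbers stand for weaker inhibition and lower numbers for stronger inhibition:
compound 1 `Cc1cc(Cl)c(S(C)(=O)=O)cc1C(=O)N=C(N)N` gives 25 nM
compound 2 `Cc1cc(C)c(S(C)(=O)=O)cc1C(=O)N=C(N)N` gives 11 nM
compound 3 `CCC(C)c1cc(C)c(C(=O)N=C(N)N)cc1S(C)(=O)=O` gives 8 nM

For the measured compounds named here, compound 3 has the lowest of the three numbers in this assay, though its gap to compound 2 lies within the scatter; only the step from compound 1 is beyond it. Compound 4 `Cc1cc(-c2ccc(Cl)cc2)c(S(C)(=O)=O)cc1C(=O)N=C(N)N` differs from compound 3 by 4-chlorophenyl in place of sec-butyl on an aromatic carbon. Going by the values given here, two measured steps touch that same aromatic carbon: a 3.1-fold lower number from compound 1 to compound 3 (0.49 log units; beyond the scatter) and a 1.4-fold lower number from compound 2 to compound 3 (0.14 log units; within the scatter). Among the compounds with values here, both point the same way, but a step from sec-butyl to an aryl ring has no measured counterpart here, so only a small step is expected: no change at the digits printed from compound 3 to compound 4 (within the scatter). Compound 4 is therefore estimated at 8 nM, with a range from 3 nM to 25 nM.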

Compound 4, half-maximal inhibitory concentration: 45 nM
Compound 4: the middle estimate sits 5.6-fold (0.75 log units) below what was measured; the whole stated range lies below it.
By their numbers in this assay, from the lowest: compounds 3 and 2 (each within the scatter of the next); then compounds 1 and 4 (each within the scatter of the next).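

In this assay, the aromatic carbon ortho to the methylsulfonyl group, where swapping between alkyl groups had moved the number little, now shows a clear cost for an aryl ring, with a 5.6-fold higher number from compound 3 to compound 4 (0.75 log units; beyond the scatter) and a 4.1-fold higher number from compound 2 to compound 4 (0.61 log units; beyond the scatter). Against chloro the picture differs, since a 1.8-fold higher number from compound 1 to compound 4 (0.26 log units; within the scatter) leaves the aryl group and chloro indistinguishable on this read-out. Nothing at hand explains the rise over the alkyl groups. As far as these compounds go, whether it belongs to the aromatic ring itself or to its chlorine stays open; an unsubstituted phenyl and a cyclohexyl group on this carbon would separate those readings.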